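The source may hold more compounds than are shown below. What is called first, only, known or untested is meant among the compounds shown, and "the series" means these compounds.

Three compounds have been measured so far:

- Compound 1, `O=S(=O)(Nc1ccc(-c2nc3cc(NS(=O)(=O)c4ccccc4O)ccc3o2)cc1)c1ccccc1O`, gives 18000 nM in an assay on cells for inhibition of HSP60/HSP10 (Homo sapiens), with a stated time of 60 min; a higher number here means a weaker inhibitor, a lower number a stronger inhibitor.
- Compound 2, `Cc1ccccc1S(=O)(=O)Nc1ccc2oc(-c3ccccc3)nc2c1`, gives > 100000 nM in this assay.
- Compound 3, `O=S(=O)(Nc1ccc(-c2nc3ccccc3o2)cc1)c1cccc(Cl)c1`, gives 54000 nM in this assay.

Compound 2 stands apart from the other two in that its result is not a number at all but a limit of the assay: the limit of > 100000 nM in this assay, at which 1 of the 3 values shown sits. Compound 2 therefore counts as a very weak inhibitor, and how weak exactly is not known.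

Compound 4, `O=S(=O)(Nc1ccc2oc(-c3ccccc3)nc2c1)c1cccc(Cl)c1`, has not yet been measured. It differs from compound 2 in one place: 3-chlorophenyl in place of 2-methylphenyl on a sulfonyl sulfur. Compound 3 also carries a 3-chlorophenyl group on its sulfonyl sulfur, though on a differently built core, and gives 54000 nM, which is still weak.

Going by the values given here, no step between two measured compounds is available to set the size of this change. The expectation for compound 4 is a weak inhibitor as well, with the step of an at least 1.2-fold lower number from compound 2 to compound 4 (0.09 log units; that floor lies within the scatter) estimated as small, quite possibly no larger than the scatter. Compound 4 is expected to give about 80000 nM, with a likely range from 20000 nM to 300000 nM.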

Compound 4, half-maximal inhibitory concentration: > 100000 nM
Compound 4 ended at the assay's limit (the forecaster's own chance of this, stated with the estimate: 55%); at least 1.2-fold (0.09 log units) between middle value and limit.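

No step can be read from compound 2 to compound 4, because both results are limits of the assay rather than numbers: the limit of > 100000 nM in this assay, at which 2 of the 4 values shown sit.

The compounds shown leave open how weak compound 2 and compound 4 really are, and whether 3-chlorophenyl in place of 2-methylphenyl on a sulfonyl sulfur changes inhibition at all.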